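Nitrophenyl for methyl on the sulfonyl sulfur of compound 1

The compounds below may be only part of what the source reports. "The series", "measured", "known", "first", "only" and "open" are said of these compounds alone.

Measured so far in a functional assay on A549 cells (Homo sapiens) for cytotoxicity, read by MTT assay, with a stated time of 48 h; on this read-out lower numbers stand for stronger inhibition and higher numbers for weaker inhibition:
compound 1 `CCN(CC)c1ccc2cc(C(=O)c3ccc(N4CCN(S(C)(=O)=O)CC4)cc3)oc2c1` — > 40000 nM
compound 2 `CCN(CC)c1ccc2cc(C(=O)c3ccc(N4CCN(S(=O)(=O)c5ccc(C)cc5)CC4)cc3)oc2c1` — > 40000 nM
compound 3 `CCN(CC)c1ccc2cc(C(=O)c3ccc(N4CCN(C(=O)COc5ccc(Cl)cc5Cl)CC4)cc3)oc2c1` — 5730 nM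

Compound 1 stands only at a limit in this assay, with no number of its own. Compound 2 also sits at a limit there, not at a number. Compound 3 alone gives a number, and the steps of an at least 6.9-fold lower number from compound 1 to compound 3 (0.84 log units; beyond the scatter) and an at least 6.9-fold lower number from compound 2 to compound 3 (0.84 log units; beyond the scatter) show that the ((2,4-dichlorophenoxy)methyl)carbonyl group moves the read-out beyond the scatter, while a step that the two limits leave unreadable from compound 1 to compound 2 cannot be sized because of the limit of > 40000 nM in this assay, at which 2 of the 3 values shown sit.

Compound 4 `CCN(CC)c1ccc2cc(C(=O)c3ccc(N4CCN(S(=O)(=O)c5ccc([N+](=O)[O-])cc5)CC4)cc3)oc2c1` carries the change (4-nitrophenyl in place of methyl on a sulfonyl sulfur). Among the measured compounds shown here, the nearest measured step is the one from compound 1 to compound 2, where a different aryl group on the same sulfonyl sulfur left the value at the limit; nothing measured separates a 4-nitrophenyl from a 4-methylphenyl on that sulfur. The expected outcome for compound 4 is therefore a value close to the limit again, the estimated step being a step that the limit leaves unreadable from compound 1 to compound 4. Compound 4 is thus expected at 45000 nM, within the range 15000 nM to 150000 nM, most probably reported only as a limit.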

Compound 4, half-maximal inhibitory concentration: 24400 nM
The estimate for compound 4 lay 1.8-fold (0.27 log units) above the measured number, within the range that was stated.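

In this assay, a sulfonyl compound now gives a number rather than a limit, with compound 4 at 24400 nM. The two steps from the sulfonyl compounds held at a limit are an at least 1.6-fold lower number from compound 1 to compound 4 (0.21 log units; that floor lies within the scatter) and an at least 1.6-fold lower number from compound 2 to compound 4 (0.21 log units; that floor lies within the scatter), so neither floor clears the scatter and any gain from 4-nitrophenyl on the sulfonyl sulfur remains unsized: the limit of > 40000 nM in this assay, at which 2 of the 4 values shown sit. The step of a 4.3-fold higher number from compound 3 to compound 4 (0.63 log units; beyond the scatter) shows that, on the amine nitrogen in a ring, (4-nitrophenyl)sulfonyl does not match the ((2,4-dichlorophenoxy)methyl)carbonyl group of compound 3.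

The compounds shown leave open whether the number depends on the nitro group itself or would also appear with another group on the aromatic carbon. A 4-aminophenyl or a 4-chlorophenyl on the same sulfonyl sulfur would test this.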